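Taking the cyclopropylsulfonyl off compound 1

The source may report more compounds than this note shows. Statements on the series, on what has been measured and on what is new or still open speak of the compounds shown alone.

Compound 1 `O=S(=O)(Nc1cccc2c1CCCC2c1c[nH]cn1)C1CC1` gives < 10000 nM in an assay on isolated protein (Cricetulus griseus) for binding affinity to Alpha-1B adrenergic receptor (Mesocricetus auratus), read by radioligand binding; on this read-out lower numbers stand for stronger inhibition and higher numbers for weaker inhibition.
Compound 2 `CCS(=O)(=O)Nc1cccc(C2CCNC2)c1` gives < 10000 nM in this assay.
Compound 3 `CCS(=O)(=O)Nc1cc(F)cc2c1CCCC2c1c[nH]cn1` gives < 10000 nM in this assay.

For compound 1 the value in this assay is a limit of the assay, not a number. The same is true of compound 2. The same is true of compound 3. All three results therefore rest on (the limit of < 10000 nM in this assay, at which 3 of the 3 values shown sit), and none of them tells how far any compound lies inside that limit. Among the measured compounds shown here, compound 1 thus stands at the limit, with no numerical position among the others, and no step between measured compounds can be drawn.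

Compound 4 `Nc1cccc2c1CCCC2c1c[nH]cn1` is the unmeasured member of the group. It differs from compound 1 in one place: hydrogen in place of cyclopropylsulfonyl on a nitrogen on an aromatic ring. Everything else in the shared core is kept.

For the measured compounds named here, with no measured step to lean on, the expectation can only be that the change moves the value by an amount within the usual scatter, or possibly toward weaker binding. Compound 4 is expected to give about 3000 nM in this assay, with a likely range from 300 nM to 10000 nM. The step this estimate implies, a step that the limit leaves unreadable from compound 1 to compound 4, is expected to be modest and uncertain in direction.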

Compound 4, inhibition constant: 525 nM
For compound 4 the middle estimate is 5.7-fold (0.76 log units) above the measured one, within the range that was stated.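

The step between compound 1 and compound 4 cannot be read, because the result for compound 1 is a limit of the assay and not a number: the limit of < 10000 nM in this assay, at which 3 of the 4 values shown sit.

From the compounds shown here alone, what stays open is how far, and in which direction, this assay responds when hydrogen takes the place of cyclopropylsulfonyl on that nitrogen.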